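The source may report more compounds than this note shows. Statements on the series, on what has been measured and on what is new or still open speak of the compounds shown alone.

Measured compounds:
- Compound 1, `Cc1ccc(S(=O)(=O)/C(=C/c2c[nH]c3ccccc23)C(=O)c2ccc(Br)cc2)cc1`, in a functional assay on DU-145 cells (Homo sapiens) for inhibition, read by trypan blue exclusion, with a stated time of 96 h (on this read-out higher numbers stand for weaker inhibition of growth and lower numbers for stronger inhibition of growth), gives 10000 nM.
- Compound 2, `Cc1ccc(S(=O)(=O)/C(=C/c2c[nH]c3ccc(Cl)cc23)C(=O)c2ccc(Br)cc2)cc1`, in this assay gives 10000 nM.
- Compound 3, `O=C(/C(=C\c1ccc(F)cc1F)S(=O)(=O)c1ccc(Br)cc1)c1ccc(Br)cc1`, in this assay gives 7500 nM.

Compound 3 has the lowest of the three numbers shown, but both gaps to it lie within the scatter of repeated measurements, so none of the three can be called more or less potent than another. Among the compounds with values here, the one step that is directly measured, no change at the digits printed from compound 1 to compound 2 (within the scatter), concerns a different part of the molecule and a different kind of change, so it does not bear on what follows.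

Compound 4, `Cc1ccc(S(=O)(=O)/C(=C/c2ccc(F)cc2F)C(=O)c2ccc(Br)cc2)cc1`, differs from compound 3 in one place: methyl in place of bromo on an aromatic carbon. The step is 4-bromophenyl to 4-methylphenyl on the sulfonyl side. Within the data shown here, no measured pair shows this exchange, and the three values so far all sit close together. For compound 4 a change in this assay no larger than the scatter is therefore expected, giving an estimated step of a 1.1-fold higher number from compound 3 to compound 4 (0.03 log units; within the scatter). Compound 4 is expected to give about 8000 nM, in the range 3000 nM to 20000 nM.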

Compound 4, concentration for 50% growth inhibition: > 100000 nM
Compound 4: only a limit was reported; the forecaster's own chance of this, stated with the estimate: 30%; middle value at least 12-fold (1.09 log units) from the limit.
By their numbers in this assay, from the lowest: compounds 3, 1 and 2 (each within the scatter of the next). At a limit, above all of these: compound 4.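

For compound 4 the reading is a limit of the assay and not a number: the limit of > 100000 nM in this assay, at which 1 of the 4 values shown sits. This place on the ring, an aromatic carbon para to a large group, is therefore sensitive to the group it carries: with the 2,4-difluorophenyl group present, methyl in place of bromo gives an at least 13-fold higher number from compound 3 to compound 4 (1.12 log units; beyond the scatter). Methyl alone does not settle the outcome, since with methyl kept, 2,4-difluorophenyl in place of 1H-indol-3-yl gives an at least 10-fold higher number from compound 1 to compound 4 (1.00 log units; beyond the scatter), and in place of 5-chloro-1H-indol-3-yl it gives an at least 10-fold higher number from compound 2 to compound 4 (1.00 log units; beyond the scatter).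

As far as these compounds go, whether bromo is specifically favoured here, or other groups would serve as well, stays open; chloro, methoxy or an amine at this place would help to tell. Also open, from the compounds shown here alone, is whether the same exchange matters when 1H-indol-3-yl is present.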